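This account rests on a few compounds, and the source may have more. Where it says the series, first, only, none or still open, it means among the compounds named here.

Working notes on the series. In an ADME assay on BJ cells (Homo sapiens) for cytotoxicity, with a stated time of 72 h (a higher number here means that more compound is needed for the effect, a lower number that less compound is needed), compound 1 `COc1cc2ncnc(-n3nc(-c4ccccn4)nc3N)c2cc1OCCCN(C)C` gives > 25000 nM, a limit of the assay and not a number. Compound 2 `CCN(CC)C(=O)COc1cc2c(-n3nc(-c4ccccn4)nc3N)ncnc2cc1OC` gives > 25000 nM, which is also only a limit. This leaves compound 2 with no numerical position, and the evidence so far is the limit of > 25000 nM in this assay, at which 2 of the 2 values shown sit. Among the compounds with values here, the sole measured change is a step that the two limits leave unreadable from compound 1 to compound 2, so it supplies no size or direction to carry forward. Compound 3 `COc1cc2ncnc(-n3nc(-c4ccccn4)nc3N)c2cc1OCCCNC(=O)OC(C)(C)C` has 2-((tert-butoxycarbonyl)amino)ethyl in place of diethylcarbamoyl on a saturated chain carbon bound to an oxygen on an aromatic ring. With no readable step available, no change beyond the scatter is expected in this assay, and a further limit reading is the likeliest result. The expected change is a number no higher from compound 2 to compound 3 (the limit leaves the size open). For compound 3 the estimate is 25000 nM, with an expected range of 10000 nM to 50000 nM.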

Compound 3, half-maximal effective concentration: > 12000 nM
Compound 3: only a limit was reported; the forecaster's own chance of this, stated with the estimate: 80%; the middle value does not contradict the limit.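

The steps among compound 1, compound 2 and compound 3 in this assay cannot be read: all three values are limits of the assay and not numbers. The compounds shown leave open the size and direction of any difference among these three side chains.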